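Swapping phenyl for isopropyl on compound 1

This account rests on a few compounds, and the source may have more. Where it says the series, first, only, none or still open, it means among the compounds named here.

Values measured in a functional assay on DLD-1 cells (Homo sapiens) for antiproliferative activity, read by CellTiter-Glo, with a stated time of 72 h (a lower number here means a stronger inhibitor, a higher number a weaker inhibitor), are these
compound 1 `CC1CCN(C2CCN(S(=O)(=O)c3ccc(-c4ccccc4)cc3)CC2)CC1` gives 258 nM
compound 2 `COc1ccc(NS(=O)(=O)N2CCC(N3CCC(C)CC3)CC2)cc1` gives 814 nM
compound 3 `CC1CCN(C2CCN(S(=O)(=O)c3ccccc3-c3ccc(Cl)cc3)CC2)CC1` gives 202 nM

Compound 1 and compound 3 lie within the scatter of each other, while compound 2 has a clearly higher number than compound 1 and so is the weaker inhibitor. Compound 4 `CC1CCN(C2CCN(S(=O)(=O)c3ccc(C(C)C)cc3)CC2)CC1` keeps the core of compound 1 but carries isopropyl in place of phenyl on an aromatic carbon, para to a large group (isopropyl in place of phenyl on an aromatic carbon). Among the measured compounds shown here, no measured pair tests this change directly. Compound 1 and compound 3 both hold a second aromatic ring, which compound 2 lacks, and compound 4 would lack it too. A moderate weakening beyond the scatter is therefore expected in this assay (a 2.3-fold higher number from compound 1 to compound 4 (0.37 log units; beyond the scatter)). Compound 4 is estimated at 600 nM with 200 nM to 1800 nM as the expected range.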

Compound 4, half-maximal inhibitory concentration: 685 nM
Compound 4: the middle estimate sits 1.1-fold (0.06 log units) below what was measured; measured number inside the range.
By their numbers in this assay, from the lowest: compounds 3 and 1 (each within the scatter of the next); then compounds 4 and 2 (each within the scatter of the next).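

In this assay, putting isopropyl in place of phenyl on this aromatic carbon, para to a large group, gives a 2.7-fold higher number from compound 1 to compound 4 (0.42 log units; beyond the scatter). This is the first direct test of the change among these compounds, and it shows that a ring-free isopropyl does not match phenyl here, although the loss is modest. No measurement shown accounts for this loss.

From the compounds shown here alone, it remains open whether an aromatic ring itself is needed at this carbon or whether any larger carbon group would serve. A cyclohexyl or pyridyl group here would help separate these possibilities.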